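A longer side chain on the shared core

The compounds below may be only part of what the source reports. "The series", "measured", "known", "first", "only" and "open" are said of these compounds alone.

Compound 1 `COc1ccc(OC)c2c1C(=O)C=C(CO)C2=O`: 0.524 ug/mL
Compound 2 `CCCCC(O)C1=CC(=O)c2c(OC)ccc(OC)c2C1=O`: 0.412 ug/mL
Compound 3 `COc1cc(C(C)O)c(OC)c2c1C(=O)C=CC2=O`: 0.132 ug/mL

All three were measured in a functional assay on L1210 cells (Mus musculus) for cytotoxicity; a lower number here means that less compound is needed, a higher number that more compound is needed for the effect. Among these numbers compound 2 gives the second highest; its nearest neighbour is compound 1, and the gap a 1.3-fold lower number from compound 1 to compound 2 (0.10 log units; within the scatter) lies within the scatter, while compound 3 sits furthest from it, beyond the scatter. Compound 4 `CCCCCCC(O)C1=CC(=O)c2c(OC)ccc(OC)c2C1=O` differs from compound 2 in one place: ethyl in place of hydrogen on a saturated chain carbon, five bonds along the chain from a double-bonded ring carbon and an oxygen on a saturated carbon. Going by the values given here, the only measured step that bears on this change, a 1.3-fold lower number from compound 1 to compound 2 (0.10 log units; within the scatter), already put butyl in place of hydrogen on that saturated chain carbon and stayed within the scatter. Lengthening the chain by ethyl is therefore expected to give no step beyond the scatter in this assay. Compound 4 is estimated at 0.4 ug/mL, with a range from 0.2 ug/mL to 0.8 ug/mL. That estimate means an expected step of a 1.0-fold lower number from compound 2 to compound 4 (0.01 log units; within the scatter), within the scatter.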

Compound 4, concentration for half-maximal effect: 0.732 ug/mL
Compound 4: middle estimate off by 1.8-fold (0.26 log units), on the low side; the range from low to high includes it.
By their numbers in this assay, from the lowest: compound 3; then compounds 2, 1 and 4 (each within the scatter of the next).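

In this assay the ethyl on the saturated chain carbon gave a 1.8-fold higher number from compound 2 to compound 4 (0.25 log units; within the scatter) and the whole hexyl in place of hydrogen gave a 1.4-fold higher number from compound 1 to compound 4 (0.15 log units; within the scatter) and both steps stay within the scatter. Compound 4 thus shows that this chain can carry ethyl beyond the butyl of compound 2 without a step beyond the scatter. No measurement offered here accounts for this result. Going by these compounds, what remains open is whether a longer chain, or an amine or a carboxylic acid at the chain end, would also stay within the scatter.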